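A few compounds are considered here, and "the series" means these few. Any claim that something is new, unique, unknown or untested is made for them only; others in the source may bear on it.

Three compounds share one core and were tested in a toxicity assay on HT-29 cells (Homo sapiens) for cytotoxicity; on this read-out lower numbers stand for higher toxicity in this test and higher numbers for lower toxicity in this test. Compound 1 `CN1C(=S)[C@@H](NC(=O)c2nc(Cc3ccccc3)n(C)n2)COc2ccccc21` gives in this assay only the limit > 100000 nM. Compound 2 `COCCn1nc(C(=O)N[C@H]2COc3ccccc3N(C)C2=S)nc1Cc1ccccc1` likewise gives only the limit > 100000 nM. Compound 3 `CN1C(=S)[C@@H](NC(=O)c2nc(Cc3ccccc3)n(C3CCCCC3)n2)COc2ccccc21` too gives only the limit > 100000 nM. Compound 2 thus stands at the limit of > 100000 nM in this assay, at which 3 of the 3 values shown sit, so no number is known for it.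

Compound 4 `CN1C(=S)[C@@H](NC(=O)c2nc(Cc3ccccc3)n(C3CCN(C(=O)OC(C)(C)C)C3)n2)COc2ccccc21` differs from compound 2 by a group of 12 heavy atoms (9 carbon, 1 nitrogen, 2 oxygen; one five-membered non-aromatic ring with 1 hetero atom) in place of a group of 4 heavy atoms (3 carbon, 1 oxygen; no ring), on an aromatic nitrogen. Within the data shown here, the steps that bear on this change are a step that the two limits leave unreadable from compound 2 to compound 3, a step that the two limits leave unreadable from compound 1 to compound 2 and a step that the two limits leave unreadable from compound 1 to compound 3; each runs between two limits, so none gives a readable size. For compound 4 no step beyond the scatter is therefore expected in this assay, the expected step being a step that the limit leaves unreadable from compound 2 to compound 4. Compound 4 is estimated at 150000 nM, within 50000 nM to 500000 nM.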

Compound 4, half-maximal cytotoxic concentration: > 100000 nM
Compound 4 was reported as a limit; the forecaster's own chance of this, stated with the estimate: 80%; the middle value lies beyond the limit too.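

Compound 4, like compounds 1, 2 and 3, gives only a limit in this assay, so no step among these four compounds can be read: the limit of > 100000 nM in this assay, at which 4 of the 4 values shown sit.

The compounds shown leave open at what concentration any of them would become toxic in this assay, and whether the group on the aromatic nitrogen changes that.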